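The source may hold more compounds than are shown below. What is called first, only, known or untested is meant among the compounds shown, and "the series" means these compounds.

Of the compounds shown here, three with the same core have been measured in a physicochemical assay for metabolic stability, read by HPLC, in phosphate buffer, at pH 7.4, tested at 10 uM; on this read-out higher numbers stand for a longer-lived compound and lower numbers for a shorter-lived compound. Compound 1 `O=C(NCCCCc1ccccc1)n1c(=O)oc2ccccc21` gives 0.75 h, compound 2 `O=C(NCCCCc1ccccc1)n1c(=O)oc2cc(Cl)ccc21` gives 0.967 h, and compound 3 `O=C(NCCCCc1ccccc1)n1c(=O)oc2cc(Br)ccc21` gives 0.4 h. Compound 2 stands at the upper end of this small set together with compound 1, and the gap between them is a 1.3-fold higher number from compound 1 to compound 2 (0.11 log units; within the scatter). Its only gap beyond the scatter is the modest one to compound 3, a 2.4-fold lower number from compound 2 to compound 3 (0.38 log units; beyond the scatter).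

The unmeasured compound 4 `O=C(NCCCCc1ccccc1)n1c(=O)oc2cc(Cl)c(Cl)cc21` differs from compound 2 in one place: chloro in place of hydrogen on an aromatic carbon. This is chloro in place of hydrogen on an aromatic carbon, ortho to a chloro group.

Among the compounds with values here, the closest precedent is the first chloro, a 1.3-fold higher number from compound 1 to compound 2 (0.11 log units; within the scatter). The bromo step points the other way, a 1.9-fold lower number from compound 1 to compound 3 (0.27 log units; within the scatter), and it too stays within the scatter. Within the data shown here, neither step shows what a second chloro does, since no measured compound carries two. With such small steps pointing in opposite directions, no clear shift is expected in this assay. The estimated step is a 1.2-fold lower number from compound 2 to compound 4 (0.08 log units; within the scatter), which would not go beyond the scatter. Compound 4 is expected to give about 0.8 h, with an estimated range from 0.4 h to 1.6 h.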

Compound 4, half-life: 0.917 h
For compound 4 the middle estimate is 1.1-fold (0.06 log units) below the measured one; low and high end bracket the measured number.
By their numbers in this assay, from the lowest: compounds 3, 1, 4 and 2 (each within the scatter of the next, the first and the last beyond it).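

In this assay, the second chloro group gives a step of a 1.1-fold lower number from compound 2 to compound 4 (0.02 log units; within the scatter), so this carbon, ortho to a chloro group, can carry a chloro without any change that can be told from the scatter. Before this result, every measured compound carried at most one halogen, so the effect of adding a second one could not be read; here, at least, adding a chloro beside the existing substituent pattern leaves the half-life indistinguishable from that of compound 2. No measurement bearing on the reason for this result is available, so the data show only the outcome and not what lies behind it.

From the compounds shown here alone, it remains open whether a chloro at this carbon would give the same result without the chloro group ortho to it, and whether a larger or very different group there, such as an amine or a carboxylic acid, would leave the half-life just as undisturbed. The compounds shown also leave open what a longer chain between the amide nitrogen and the phenyl ring would do to the half-life.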